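Benzyl to methyl on a core with limit readings

A few compounds are considered here, and "the series" means these few. Any claim that something is new, unique, unknown or untested is made for them only; others in the source may bear on it.

Of the compounds shown here, three sharing one core have been tested in a functional assay on MCF7 cells (Homo sapiens) for antiproliferative activity, read by MTT assay; on this read-out higher numbers stand for weaker inhibition and lower numbers for stronger inhibition. Compound 1 `NS(=O)(=O)c1cccc(/N=C2\NC(=O)/C(=C3/C(=O)Nc4ccccc43)S2)c1` returns only a limit, its reading in this assay standing at > 200000 nM. Compound 2 `NS(=O)(=O)c1ccc(/N=C2\NC(=O)/C(=C3/C(=O)N(Cc4ccccc4)c4ccccc43)S2)cc1` likewise returns only a limit in this assay, at > 200000 nM. For the measured compounds named here, compound 3 `NS(=O)(=O)c1ccc(/N=C2\NC(=O)/C(=C3/C(=O)N(Cc4ccccc4)c4ccc(Cl)cc43)S2)cc1` is the single member with a number, giving 124000 nM in this assay. Going by the values given here, the one step between measured compounds that differ in one place is an at least 1.6-fold lower number from compound 2 to compound 3 (0.20 log units; that floor lies within the scatter); that step lies within the scatter, its floor being set by the limit of > 200000 nM in this assay, at which 2 of the 3 values shown sit. Compound 2 therefore stands only at a limit, as does one further value in the set, and no ordering of compounds 1, 2 and 3 can be drawn from these readings.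

Compound 4 `CN1C(=O)/C(=C2\S/C(=N/c3ccc(S(N)(=O)=O)cc3)NC2=O)c2ccccc21` is related to compound 2 by hydrogen in place of phenyl on a saturated chain carbon bound to an amide-type nitrogen in a ring. Among the compounds with values here, no measured step covers this change: the only step on record, the chloro change, touches a different part of the structure and was itself within the scatter. The step of a number no higher from compound 2 to compound 4 (the limit leaves the size open) is therefore expected to stay within the scatter. Compound 4 is estimated at 200000 nM, within a range of 100000 nM to 400000 nM, with a good chance that this assay again reports only a limit.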

Compound 4, half-maximal inhibitory concentration: 51900 nM
Beside the measured number, compound 4's estimate is 3.9-fold (0.59 log units) above it; the measured number lies below the stated range.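

Hydrogen in place of phenyl on a saturated chain carbon bound to an amide-type nitrogen in a ring, the change that also reads as benzyl to methyl, gives in this assay an at least 3.8-fold lower number from compound 2 to compound 4 (0.58 log units; beyond the scatter). For the compounds shown here, the only earlier step, the chloro change, lay within the scatter and touched a different part of the structure, so this is the first place on the shared core where a single change is seen to move the reading beyond the scatter, and the move is towards stronger inhibition with the smaller group. The full size of the step cannot be given, because compound 2 stands at a limit and not at a number: the limit of > 200000 nM in this assay, at which 2 of the 4 values shown sit.

The compounds shown leave open whether the lower number belongs to methyl in particular or to the loss of the phenyl, which a longer chain such as propyl, or a chain ending in an amine or a carboxylic acid, at the same place would help to separate. They also leave open whether the chloro change and the benzyl to methyl change would combine on the shared core.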